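This account rests on a few compounds, and the source may have more. Where it says the series, first, only, none or still open, it means among the compounds named here.

Measured so far in a functional assay on MDCK cells (Canis lupus familiaris) for inhibition; a lower number here means that less compound is tolerated, a higher number that more compound is tolerated:
- compound 1 `CCCCOc1nc(CC2(c3ccccc3)CCCO2)cc(=O)n1C`: 90000 nM
- compound 2 `CCCOc1nc(CC2CCCO2)cc(=O)n1C`: 1020000 nM

Compound 2, at 1020000 nM, holds the higher of the two numbers, and compound 1 lies lower at 90000 nM; this gap is beyond the scatter. Compound 3 `CCCCOc1nc(CC2CCCO2)cc(=O)n1C` comes from compound 2 by methyl in place of hydrogen on a saturated chain carbon, three bonds along the chain from an oxygen on an aromatic ring, which reads as propyl to butyl. Among the compounds with values here, no measured pair shows this change on its own, so the expectation rests on thin ground. Compound 1, at 90000 nM, also carries the butyl chain, which points weakly toward lower numbers. In this assay a modest fall is expected, perhaps not beyond the scatter. The expected step of a 1.7-fold lower number from compound 2 to compound 3 (0.23 log units; within the scatter) is an estimate only. For compound 3 the estimated value is 600000 nM, with an expected range of 250000 nM to 1300000 nM.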

Compound 3, half-maximal cytotoxic concentration: 579000 nM
Compound 3: middle estimate off by 1.0-fold (0.02 log units), on the high side; the measured number falls inside the stated range.
By their numbers in this assay, from the lowest: compound 1; then compounds 3 and 2 (each within the scatter of the next).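

In this assay the change from propyl to butyl, on a saturated chain carbon three bonds along the chain from an oxygen on an aromatic ring, gives a 1.8-fold lower number from compound 2 to compound 3 (0.25 log units; within the scatter) and so does not separate the two compounds. Within the data shown here, with butyl held in place, hydrogen in place of phenyl on a saturated ring carbon gives a 6.4-fold higher number from compound 1 to compound 3 (0.81 log units; beyond the scatter) and is the first single-place change here that lies beyond the scatter. Among these single-place steps, the larger gap goes with the phenyl and not with the butyl chain.

The data on hand give no cause for either step. Open questions are whether a chain longer than butyl or an amine at the end of the chain would give a step beyond the scatter, and whether phenyl has a step of similar size alongside propyl.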